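The compounds below may be only part of what the source reports. "The series", "measured", "known", "first", "only" and "open" are said of these compounds alone.

Working notes on the series. In a functional assay on cells (Cancer cell lines, Homo sapiens) for cytotoxicity, read by sulforhodamine B assay, with a stated time of 48 h (on this read-out lower numbers stand for stronger inhibition of growth and higher numbers for weaker inhibition of growth), compound 3 `NS(=O)(=O)c1ccc(-n2nc(-c3ccccc3)cc2-c2cc(O)ccc2O)cc1` gives 81300 nM, the highest of the three numbers; compound 2 `Oc1ccc(O)c(-c2cc(-c3ccccc3)nn2-c2ccccc2)c1` gives 37700 nM and compound 1 `COc1ccc(OC)c(-c2cc(-c3ccccc3)nn2-c2ccc(S(=O)(=O)NC(C)=O)cc2)c1` gives 13300 nM. Within the data shown here, the only single-point step measured is a 2.2-fold higher number from compound 2 to compound 3 (0.33 log units; beyond the scatter), which is not the change now considered. Compound 4 `CC(=O)NS(=O)(=O)c1ccc(-n2nc(-c3ccccc3)cc2-c2cc(O)ccc2O)cc1` differs from compound 3 by acetyl in place of hydrogen on a sulfonamide nitrogen. Compound 1 also carries the acetylsulfamoyl group but differs from compound 4 in two places, so its value only shows that such a group is compatible with a lower number. Among the measured compounds shown here, no measured step bears directly on the acetylation, so for compound 4 a step of a 1.6-fold lower number from compound 3 to compound 4 (0.21 log units; within the scatter) in this assay is expected, not clearly beyond the scatter. Compound 4 is estimated at 50000 nM, range 15000 nM to 160000 nM.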

Compound 4, concentration for 50% growth inhibition: 100000 nM
Compound 4: middle estimate off by 2.0-fold (0.30 log units), on the low side, and the stated range covers the measured number.
By their numbers in this assay, from the lowest: compound 1; then compound 2; then compounds 3 and 4 (each within the scatter of the next).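

In this assay the step of a 1.2-fold higher number from compound 3 to compound 4 (0.09 log units; within the scatter) shows that acetyl on the sulfonamide nitrogen does not move the number beyond the scatter when 2,5-dihydroxyphenyl is present. The step of a 2.7-fold higher number from compound 2 to compound 4 (0.42 log units; beyond the scatter) stays modest, and the step of a 7.5-fold higher number from compound 1 to compound 4 (0.88 log units; beyond the scatter) ties the lower number of compound 1 to 2,5-dimethoxyphenyl rather than to the acetylsulfamoyl group. No measurement on hand explains these steps.

As far as these compounds go, whether a propionyl or methyl group on the sulfonamide nitrogen would give a step beyond the scatter stays open. Also open, from the compounds shown here alone, is whether the acetyl step holds with 2,5-dimethoxyphenyl in place.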